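This account rests on a few compounds, and the source may have more. Where it says the series, first, only, none or still open, it means among the compounds named here.

Going by the values given here, compound 2 `C/C(CC(C)C)=N/Nc1nc(-c2cccc([N+](=O)[O-])c2)cs1` gives the lowest of the two numbers so far in an assay on isolated protein for inhibition of Amine oxidase [flavin-containing] B (Homo sapiens), read by fluorescence, with a stated time of 20 min (a lower number here means a stronger inhibitor, a higher number a weaker inhibitor), at 12 nM. Among the compounds with values here, compound 1 `CCC(CC)=NNc1nc(-c2cccc([N+](=O)[O-])c2)cs1` gives 53 nM, and the only step measured, a 4.4-fold lower number from compound 1 to compound 2 (0.65 log units; beyond the scatter), came from swapping one chain for a slightly larger one on a nitrogen on an aromatic ring. Compound 3 `CCCC/C(C)=N\Nc1nc(-c2cccc([N+](=O)[O-])c2)cs1` keeps the same atoms as compound 2 but joined differently: propyl in place of isopropyl on a saturated chain carbon bound to a carbon with a double bond to nitrogen. Within the data shown here, no measured step tests such a rearrangement, so compound 3 is expected to stay close to compound 2, with a change of about a 1.3-fold higher number from compound 2 to compound 3 (0.10 log units; within the scatter), and is estimated at 15 nM, within 5 nM to 45 nM.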

Compound 3, half-maximal inhibitory concentration: 118 nM
Compound 3: the middle estimate sits 7.9-fold (0.90 log units) below what was measured; measured number outside the range, above it.
By their numbers in this assay, from the lowest: compound 2; then compound 1; then compound 3.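

Along this chain, on a saturated chain carbon bound to a carbon with a double bond to nitrogen, how the atoms are joined matters as well as how many there are: propyl in place of isopropyl gives a 9.8-fold higher number from compound 2 to compound 3 (0.99 log units; beyond the scatter). Adding to the chain therefore does not lower the number by itself, since a 2.2-fold higher number from compound 1 to compound 3 (0.35 log units; beyond the scatter) runs the opposite way to a 4.4-fold lower number from compound 1 to compound 2 (0.65 log units; beyond the scatter). Nothing available explains this difference.

Still open, going by these compounds, is whether a tert-butyl group or a cyclohexyl ring here would keep the number as low as isopropyl does. A longer chain such as pentyl is also untested among these compounds.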